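The compounds below may be only part of what the source reports. "The series", "measured", "known", "first", "only" and "open" are said of these compounds alone.

Measured in a functional assay on HeLa cells (Homo sapiens) for inhibition, read by trypan blue exclusion, with a stated time of 72 h; on this read-out higher numbers stand for weaker inhibition of growth and lower numbers for stronger inhibition of growth:

- Compound 1 `CC/C(=C(/c1ccccc1)c1ccc(NC(=O)C(C)C)cc1)c1ccc(OCc2ccccc2)cc1`: > 30000 nM
- Compound 2 `CC/C(=C(/c1ccccc1)c1ccc(NC(=O)C(C)C)cc1)c1ccc(Cl)cc1Cl`: 8200 nM

The reading for compound 1 is a limit of the assay, not a number: the limit of > 30000 nM in this assay, at which 1 of the 2 values shown sits. Within the data shown here, compound 2 therefore holds the only numerical value so far, and its position can only be set against that limit.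

The next compound to compare with compound 2 is compound 3 `CC/C(=C(/c1ccccc1)c1ccc(NC(=O)C(C)C)cc1)c1ccc(O)cc1`. It has 4-hydroxyphenyl in place of 2,4-dichlorophenyl on a double-bonded chain carbon bound to a double-bonded chain carbon and a saturated chain carbon.

Among the measured compounds shown here, no measured step between compounds that differ in one place is available to size this change. The expectation therefore rests on compound 2 at 8200 nM and carries a wide range. No shift beyond the usual scatter is expected in this assay, and the estimated change is a 1.4-fold lower number from compound 2 to compound 3 (0.14 log units; within the scatter). A reading reported only as a limit, as for compound 1, remains possible.

For compound 3 the expected value is 6000 nM, with an estimated range of 1800 nM to 25000 nM.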

Compound 3, concentration for 50% growth inhibition: 5100 nM
The estimate for compound 3 lay 1.2-fold (0.07 log units) above the measured number; the range from low to high includes it.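

In this assay, the position on a double-bonded chain carbon bound to a double-bonded chain carbon and a saturated chain carbon accepts 4-hydroxyphenyl in place of 2,4-dichlorophenyl with no shift that can be told from the scatter, so these two groups, which differ in their chlorine and oxygen atoms and in their hydrogen-bond donor and acceptor counts, cannot be separated on this read-out: a 1.6-fold lower number from compound 2 to compound 3 (0.21 log units; within the scatter). Among these compounds, the substituent on the oxygen does register, and hydrogen in place of benzyl on an oxygen on an aromatic ring gives the only step that is beyond the scatter: an at least 5.8-fold lower number from compound 1 to compound 3 (0.76 log units; beyond the scatter). As far as these compounds go, the reading for compound 1 is a limit and not a number, so this step has a lower bound only, and its full size remains unknown: the limit of > 30000 nM in this assay, at which 1 of the 3 values shown sits.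

The compounds shown leave open whether a methyl ether on that oxygen would read like the hydroxyl of compound 3 or like the benzyl ether of compound 1. They also leave open how an amine or a carboxylic acid on the same aromatic ring would read in this assay.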